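Pyridin-3-yl Carbonyl in Place of Acetyl on a Shared Core

The source may hold more compounds than are shown below. What is called first, only, known or untested is meant among the compounds shown, and "the series" means these compounds.

Measured compounds:
Compound 1 `CC(=O)Nc1nc(C)nc2cn(-c3ccccc3)nc12`: 300 nM
Compound 2 `Cc1nc(N(C(=O)c2ccccc2)C(=O)c2ccccc2)c2nn(-c3ccccc3)cc2n1`: 33 nM
Compound 3 `O=C(Nc1nc(-c2ccccc2)nc2cn(-c3ccccc3)nc12)c1ccncc1`: 25 nM

In an assay on CHO cells for displacement of a labelled ligand from adenosine receptor A3 (Homo sapiens), read by scintillation counting, with a stated time of 60 min (on this read-out lower numbers stand for stronger inhibition and higher numbers for weaker inhibition), compound 1 gives the highest of the three numbers; compound 2 and compound 3 both sit well below it, beyond the scatter. Compound 4 `Cc1nc(NC(=O)c2cccnc2)c2nn(-c3ccccc3)cc2n1` has not been measured in this assay. It differs from compound 1 by pyridin-3-yl in place of methyl on a carbonyl carbon. Within the data shown here, no measured pair shows exactly this change, but compound 2 and compound 3, each carrying an aromatic acyl group, give lower numbers than compound 1. The step from compound 1 to compound 4 is therefore expected to be a clear drop, a 6.0-fold lower number from compound 1 to compound 4 (0.78 log units; beyond the scatter). Compound 4 is estimated at 50 nM, within 15 nM to 200 nM.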

Compound 4, inhibition constant: 5.3 nM
Beside the measured number, compound 4's estimate is 9.4-fold (0.97 log units) above it, outside the stated range (below it).
By their numbers in this assay, from the lowest: compound 4; then compounds 3 and 2 (each within the scatter of the next); then compound 1.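

In this assay, among these compounds, pyridin-3-yl in place of methyl on a carbonyl carbon gives a 57-fold lower number from compound 1 to compound 4 (1.75 log units; beyond the scatter) as a clean single change, which the earlier compounds, differing from compound 1 in more than one place, could not show. On the shared core, this position therefore accepts the larger aromatic group and responds strongly to the change. No measurement on hand accounts for the size of this step. Going by these compounds, whether a cyclohexyl group or a longer alkyl chain in the same place would give a similar number remains open. The compounds shown also leave open whether the ring nitrogen of pyridin-3-yl matters, since no carbon-only ring appears alone in this place.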